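Naphthyl-pyridine series: saturating the side chain, adding a hydrazide

The compounds below may be only part of what the source reports. "The series", "measured", "known", "first", "only" and "open" are said of these compounds alone.

For the measured compounds named here, compound 1 `NC(=O)/C=C/c1ccncc1-c1ccc2ccccc2c1` and compound 2 `Cn1ccc2cc(-c3cnccc3/C=C/C(=O)O)ccc21` are the two measured members. In an assay on a protein complex for inhibition of CDK8/Cyclin C (Homo sapiens), with a stated time of 1 h, tested at 10 uM (on this read-out higher numbers stand for more inhibition at the one concentration tested (going by the name of the read-out) and lower numbers for less inhibition), compound 1 gives 102%, and compound 2 gives 102% in this assay; the two values stand level at the digits given, so no order between them can be read. Both sit at the top of the read-out, which leaves the size of any downward step open.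

Compound 3 `NNC(=O)CCc1ccncc1-c1ccc2ccccc2c1` is not yet measured. It differs from compound 1 as follows: 2-(aminocarbamoyl)ethyl in place of 2-carbamoylethenyl on an aromatic carbon. Going by the values given here, no measured pair spans such a change, so the expectation rests on the two values alone. Compound 3 is expected to fall somewhat, with a step from compound 1 of about a number 22 percentage points lower from compound 1 to compound 3 (beyond the scatter) in this assay. Compound 3 is estimated at 80%, in the range 40% to 103%.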

Compound 3, a percentage reported as inhibition, at one concentration (the size of the read-out at that concentration, not a potency): 102%
The estimate for compound 3 lay 22 percentage points below the measured number, within the range that was stated.
By their numbers in this assay, from the lowest: compounds 1, 2 and 3 (each within the scatter of the next).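

In this assay, 2-(aminocarbamoyl)ethyl in place of 2-carbamoylethenyl on the aromatic carbon opposite the ring nitrogen gives no change at the digits printed from compound 1 to compound 3 (within the scatter). For the compounds shown here, this is the first single-place comparison, and the number in this read-out stands level across the change from the unsaturated amide chain to the saturated hydrazide chain, with its 2 hydrogen-bond donors and 2 hydrogen-bond acceptors. No supporting data bear on this result.

All three compounds sit at the top of a read-out taken at a single concentration, so any difference in potency among them stays hidden. Also open, from the compounds shown here alone, is whether a simple amine, a carboxylic acid on the saturated chain or a longer chain at this position would hold the same level.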